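The source may report more compounds than this note shows. Statements on the series, on what has been measured and on what is new or still open speak of the compounds shown alone.

Measured compounds:
Compound 1, `COC(=O)c1c(Nc2ccc(F)cc2)sc(C(=O)c2ccc(OC)cc2)c1C`, in a functional assay, with a stated time of 150 min, tested at 35 ug/mL (on this read-out higher numbers stand for a stronger effect at the one concentration tested and lower numbers for a weaker effect), compound 1 gives 25.6%.
Compound 2, `COC(=O)c1c(Nc2ccccc2)sc(C(=O)c2ccc(C)cc2)c1C`, in this assay compound 2 gives 10.3%.
Compound 3, `COC(=O)c1c(Nc2ccc(C)cc2)sc(C(=O)c2ccc(C)cc2)c1C`, in this assay compound 3 gives "not active" (no number reported), with no number given.

Within the data shown here, compound 3 thus stands at the bottom of what has been measured in this assay so far, without a figure to set beside compound 1 or compound 2. Compound 1 and compound 2 differ from each other in more than one place, so nothing about a single change can be read from their two values; they only show that the series as a whole sits in the low range of this read-out.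

Compound 4, `COC(=O)c1c(Nc2ccc(F)cc2)sc(C(=O)c2ccc(C)cc2)c1C`, has not yet been measured in this assay. It differs from compound 3 by fluoro in place of methyl on an aromatic carbon. Among the measured compounds shown here, no measured pair isolates this change, so no step of known size can be carried over. The expectation is for a small shift at most, likely upward from the inactive report for compound 3 but not clearly beyond the usual scatter, since compound 2, which shares the same benzoyl part, gives only 10.3%.

Compound 4 is expected to give about 9% in this assay, within a range from 0% to 22%.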

Compound 4, a percentage reported as activity, at one concentration (the size of the read-out at that concentration, not a potency): "not active" (no number reported)
Nothing numeric was reported for compound 4, so the estimate cannot be set against anything.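

In this assay compound 3 gives "not active" (no number reported) and compound 4 gives "not active" (no number reported), so no step can be read between compound 3 and compound 4. No measurement shown bears on this result. The compounds shown leave open whether (4-methylphenyl)amino and (4-fluorophenyl)amino differ at all in this read-out.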